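Replacing the Acetylpiperidine of Compound 2

A few compounds are considered here, and "the series" means these few. Any claim that something is new, unique, unknown or untested is made for them only; others in the source may bear on it.

Among the compounds with values here, in an ADME assay on microsomes from liver (Homo sapiens) for metabolic stability, with a stated time of 10 min (on this read-out lower numbers stand for a less stable compound and higher numbers for a more stable compound), compound 2 `CC(=O)N1CCC(c2nnc3c(Oc4cccc(Cl)c4C)cccn23)CC1` gives 87%, the lower of the two numbers so far, and compound 1 `Cc1c(Cl)cccc1Oc1cccn2c(C3CCC(C)(O)CC3)nnc12` gives 99%. Compound 3 `Cc1c(Cl)cccc1Oc1cccn2c(C3CCCCCC3O)nnc12` has 2-hydroxycycloheptyl in place of 1-acetylpiperidin-4-yl on an aromatic carbon of the shared core: 2-hydroxycycloheptyl in place of 1-acetylpiperidin-4-yl on an aromatic carbon. Within the data shown here, one measured step bears on this exchange, a modest one that introduced the same 1-acetylpiperidin-4-yl group: a number 12 percentage points lower from compound 1 to compound 2 (beyond the scatter). Among the measured compounds shown here, no measured compound carries 2-hydroxycycloheptyl, so only part of that step is expected to return. The expected change is a number 3 percentage points higher from compound 2 to compound 3 (within the scatter) in this assay, with no clear step beyond the scatter. For compound 3 the estimated value is 90%, with an expected range of 74% to 100%.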

Compound 3, percent of the compound remaining: 81%
The estimate for compound 3 lay 9 percentage points above the measured number; low and high end bracket the measured number.
By their numbers in this assay, from the lowest: compounds 3 and 2 (each within the scatter of the next); then compound 1.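

At this place on the aromatic carbon, 2-hydroxycycloheptyl in place of 1-acetylpiperidin-4-yl comes out as a number 6 percentage points lower from compound 2 to compound 3 (within the scatter) in this assay and so gives no clear step. Against 4-hydroxy-4-methylcyclohexyl the same group gives a number 18 percentage points lower from compound 1 to compound 3 (beyond the scatter) and thus shows that a hydroxy group on an all-carbon ring does not by itself carry the number of compound 1 to compound 3. Nothing available here explains either step. Going by these compounds, whether an amine, a carboxylic acid or a longer chain at this place would hold up in this assay stays open.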